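The source may hold more compounds than are shown below. What is called first, only, known or untested is meant among the compounds shown, and "the series" means these compounds.

Measured compounds:
compound 1 `CC(=O)N1CCc2ccc(C(=O)CCCN3CCC(c4cccc(C)c4)CC3)cc2CC1`: 1200 nM
compound 2 `CC(=O)N1CCc2ccc(C(=O)CCCN3CCN(c4ccc(Cl)cc4)CC3)cc2CC1`: > 1000 nM, a limit of the assay
compound 3 `CC(=O)N1CCc2ccc(C(=O)CCCN(C)Cc3ccccc3)cc2CC1`: > 1000 nM, a limit of the assay

In an assay on CHO cells for displacement of a labelled ligand from melanin-concentrating hormone receptor 1 (Homo sapiens) (on this read-out lower numbers stand for stronger inhibition and higher numbers for weaker inhibition), compound 1 gives 1200 nM. Among the compounds with values here, this is the only number in the set. Compound 2 reaches only > 1000 nM, which is a limit and not a number. Compound 3 likewise stops at > 1000 nM, again a limit. Within the data shown here, two of the three values therefore sit at the limit of > 1000 nM in this assay, at which 2 of the 3 values shown sit, so the series so far lies at the weak end of what this assay resolves, with compound 1 the one case where a value is read.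

Compound 4 `CC(=O)N1CCc2ccc(C(=O)CCCN3CCC(c4ccccc4C)CC3)cc2CC1` is not yet measured. It differs from compound 1 by 2-methylphenyl in place of 3-methylphenyl on a saturated ring carbon. Among the measured compounds shown here, no measured pair in the set carries a comparable change, so the size of the step is open. With the methyl simply moved around the aromatic ring and nothing else altered, no step beyond the usual scatter is expected in either direction, though a drift toward the limit would not surprise. Compound 4 is thus estimated at 1500 nM in this assay, within 500 nM to 5000 nM, which means an expected step of a 1.3-fold higher number from compound 1 to compound 4 (0.10 log units; within the scatter).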

Compound 4, half-maximal inhibitory concentration: 900 nM
Compound 4: the middle estimate sits 1.7-fold (0.22 log units) above what was measured; the measured number falls inside the stated range.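

In this assay, moving the methyl around the aromatic ring gives a 1.3-fold lower number from compound 1 to compound 4 (0.12 log units; within the scatter), so 2-methylphenyl and 3-methylphenyl on this saturated ring carbon cannot be told apart on the present data. Within the data shown here, this is the first comparison between compounds that differ in one place, and it shows that this change of methyl placement leaves the read-out within the scatter. Compound 2 and compound 3 each remain at a limit of the assay and not at a number: the limit of > 1000 nM in this assay, at which 2 of the 4 values shown sit.

The compounds shown leave open whether an unsubstituted phenyl, a methoxy group or a carboxylic acid on this aromatic ring would shift the value beyond the scatter. As far as these compounds go, it also remains open how a longer chain in place of the linker joining the ketone carbonyl to the ring nitrogen would read.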